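Ester Changes and Cell Tolerance in a Shared Core

This account rests on a few compounds, and the source may have more. Where it says the series, first, only, none or still open, it means among the compounds named here.

Measured so far in an ADME assay on HepG2 2.2.15 cells (Homo sapiens) for cytotoxicity; a higher number here means that more compound is tolerated, a lower number that less compound is tolerated:
compound 1 `CCCC(=O)OCCc1c(-c2ccccc2Cl)c2cc(Cl)ccc2[nH]c1=O` gives 52000 nM
compound 2 `CCOCC(=O)OCCc1c(-c2ccccc2Cl)c2cc(Cl)ccc2[nH]c1=O` gives 130000 nM
compound 3 `O=C(OCCc1c(-c2ccccc2Cl)c2cc(Cl)ccc2[nH]c1=O)c1ccccc1` gives 43000 nM

Compound 3 has the lowest of the three numbers in this assay, yet compound 1 lies within the scatter of it, and only compound 2 stands clearly apart, as the step of a 3.0-fold lower number from compound 2 to compound 3 (0.48 log units; beyond the scatter) shows. Compound 4 `O=C(/C=C/c1cccc(F)c1)OCCc1c(-c2ccccc2Cl)c2cc(Cl)ccc2[nH]c1=O` differs from compound 3 in one place: 2-(3-fluorophenyl)ethenyl in place of phenyl on a carbonyl carbon. Within the data shown here, no measured step alters the group on the carbonyl carbon in just this way. The two steps that lead to compound 3, a 1.2-fold lower number from compound 1 to compound 3 (0.08 log units; within the scatter) and a 3.0-fold lower number from compound 2 to compound 3 (0.48 log units; beyond the scatter), are within the scatter or modest, so a further change on the carbonyl carbon is expected to move this assay little, with no step beyond the scatter. Compound 4 is therefore estimated at 40000 nM, in the range 15000 nM to 110000 nM, an expected step of a 1.1-fold lower number from compound 3 to compound 4 (0.03 log units; within the scatter).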

Compound 4, half-maximal cytotoxic concentration: > 1600000 nM
Compound 4: a limit, no number; the forecaster's own chance of this, stated with the estimate: 10%; middle value at least 40-fold (1.60 log units) from the limit.
By their numbers in this assay, from the lowest: compounds 3 and 1 (each within the scatter of the next); then compound 2. At a limit, above all of these: compound 4.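

On the carbonyl carbon, 2-(3-fluorophenyl)ethenyl shifts this assay far more than the exchanges among propyl, ethoxymethyl and phenyl did: an at least 37-fold higher number from compound 3 to compound 4 (1.57 log units; beyond the scatter), an at least 12-fold higher number from compound 2 to compound 4 (1.09 log units; beyond the scatter) and an at least 30-fold higher number from compound 1 to compound 4 (1.48 log units; beyond the scatter). This position can therefore carry a large change in tolerated concentration, not only the modest ones seen earlier. Compound 4 gives a limit, not a number: the limit of > 1600000 nM in this assay, at which 1 of the 4 values shown sits.

Open, going by these compounds, is whether the double bond or the fluorine accounts for the step. A plain 2-phenylethenyl group or a saturated 2-(3-fluorophenyl)ethyl chain would help separate the two.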